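This account rests on a few compounds, and the source may have more. Where it says the series, first, only, none or still open, it means among the compounds named here.

Compound 1 `COc1ccc(S(=O)(=O)N2CCc3cccc(NC(=O)C(C)(C)C)c32)cc1` is the starting point here. In a functional assay on MKN-45 cells (Homo sapiens) for cytotoxicity (a lower number here means a stronger inhibitor, a higher number a weaker inhibitor), compound 1 gives 289 nM, the lowest of the two plain numbers shown. Compound 2 `COc1ccc(S(=O)(=O)N2CCc3cccc(NS(=O)(=O)c4ccc(F)cc4)c32)cc1` gives 890 nM in this assay. Compound 3 `COc1ccc(S(=O)(=O)N2CCc3cccc(NC(=O)Oc4ccccc4)c32)cc1` reaches only a limit of this assay, > 10000 nM. That limit is recorded as the limit of > 10000 nM in this assay, at which 1 of the 3 values shown sits.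

Compound 4 `COc1ccc(S(=O)(=O)N2CCc3cccc(NS(=O)(=O)c4ccccc4)c32)cc1` has not yet been measured in this assay. Compared with compound 1 the change is phenylsulfonyl in place of (tert-butyl)carbonyl on a nitrogen on an aromatic ring. Of the measured steps, the one that bears on this is a 3.1-fold higher number from compound 1 to compound 2 (0.49 log units; beyond the scatter), since compound 2 carries (4-fluorophenyl)sulfonyl where compound 4 carries phenylsulfonyl, both on the same nitrogen. The step to compound 3, an at least 34-fold higher number from compound 1 to compound 3 (1.53 log units; beyond the scatter), swaps in a phenoxycarbonyl instead and is less closely related. A modest rise in the number is therefore expected for compound 4, a step of a 3.1-fold higher number from compound 1 to compound 4 (0.49 log units; beyond the scatter), and the estimated value for compound 4 is 900 nM, with a range from 300 nM to 3000 nM.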

Compound 4, half-maximal inhibitory concentration: 562 nM
For compound 4 the middle estimate is 1.6-fold (0.20 log units) above the measured one; low and high end bracket the measured number.
By their numbers in this assay, from the lowest: compounds 1, 4 and 2 (each within the scatter of the next, the first and the last beyond it). At a limit, above all of these: compound 3.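

Taken without the fluoro, the swap of (tert-butyl)carbonyl for phenylsulfonyl on this nitrogen gives a 1.9-fold higher number from compound 1 to compound 4 (0.29 log units; within the scatter), so this sulfonyl group cannot be told apart from the (tert-butyl)carbonyl group in this assay. Removing the fluoro gives a 1.6-fold lower number from compound 2 to compound 4 (0.20 log units; within the scatter), so this single atom on the aromatic ring makes no readable difference here. Phenylsulfonyl also gives an at least 17-fold lower number from compound 3 to compound 4 (1.25 log units; beyond the scatter), and compound 3 remains at a limit of the assay: the limit of > 10000 nM in this assay, at which 1 of the 4 values shown sits.

On these data alone, what an amine or a carboxylic acid on the ring of the phenylsulfonyl group would do remains open, as does a longer chain in place of tert-butyl. The methoxy group is shared by all four compounds, so its own contribution cannot be read from them.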